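This account rests on a few compounds, and the source may have more. Where it says the series, first, only, none or still open, it means among the compounds named here.

Measured values in a functional assay on KB cells (Homo sapiens) for antiproliferative activity, read by MTT assay, with a stated time of 72 h (on this read-out higher numbers stand for weaker inhibition and lower numbers for stronger inhibition), are these:

- Compound 1 `O=C1C=C(N2CCN(c3ccccc3Cl)CC2)C(=O)c2ccccc21` gives 3700 nM
- Compound 2 `O=C1C=C(N2CCC(c3ccccc3)CC2)C(=O)c2c(O)cccc21` gives 2200 nM
- Compound 3 `O=C1C=C(N2CCC(c3ccc(Cl)cc3)CC2)C(=O)c2c(O)cccc21` gives 14000 nM

Compound 3 at 14000 nM has the highest number of the three, which here means the weakest inhibition. Compound 4 `Cc1ccccc1C1CCN(C2=CC(=O)c3cccc(O)c3C2=O)CC1` has not yet been measured. It carries 2-methylphenyl in place of 4-chlorophenyl on a saturated ring carbon.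

Among the compounds with values here, one measured step bears on this change: a 6.4-fold higher number from compound 2 to compound 3 (0.80 log units; beyond the scatter) when chloro replaces hydrogen on an aromatic carbon, a modest step. Compound 4 has no chloro, so a partial return toward compound 2 at 2200 nM is expected in this assay. Within the data shown here, no measured compound shows what the methyl does, and that keeps the expectation loose. A modest fall in the number is therefore expected, and the estimate is a 3.1-fold lower number from compound 3 to compound 4 (0.49 log units; beyond the scatter) on present evidence. Compound 4 is estimated at 4500 nM with an expected range from 1500 nM to 13000 nM on this evidence.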

Compound 4, half-maximal inhibitory concentration: 4400 nM
For compound 4 the middle estimate is 1.0-fold (0.01 log units) above the measured one; the range from low to high includes it.
By their numbers in this assay, from the lowest: compounds 2, 1 and 4 (each within the scatter of the next); then compound 3.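

In this assay, replacing 4-chlorophenyl with 2-methylphenyl on this saturated ring carbon gives a 3.2-fold lower number from compound 3 to compound 4 (0.50 log units; beyond the scatter) and shows that the poor result of compound 3 does not extend to every substituted phenyl here. Adding the methyl to the plain phenyl gives a 2.0-fold higher number from compound 2 to compound 4 (0.30 log units; within the scatter) and, as this lies within the scatter, compound 2 and compound 4 cannot be told apart, so this methyl is tolerated at this position in a way the chloro of compound 3 is not. Nothing measured here explains the difference between the two substituted phenyl groups.

This change alters both the group and its place on the phenyl, and the compounds shown do not separate the two. Also open, going by these compounds, is how a phenyl carrying a methoxy group or an amine would read in this assay.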